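Amide nitrogen substituent swap across two cores

The source may report more compounds than this note shows. Statements on the series, on what has been measured and on what is new or still open speak of the compounds shown alone.

Compound 2 `CCOC(=O)[C@]1(C(=O)NCc2ccc(C)cc2)C[C@H]1c1cc(OC)c(OC)c(OC)c1` carries a 4-methylbenzyl group on the amide-type nitrogen; in a functional assay on HeLa cells (Homo sapiens) for cytotoxicity, read by MTT assay, with a stated time of 48 h (on this read-out higher numbers stand for weaker inhibition and lower numbers for stronger inhibition), compound 2 gives 28500 nM. Compound 1 `CCOC(=O)[C@]1(C(=O)Nc2ccccc2)C[C@H]1c1cc(OC)c(OC)c(OC)c1` is its phenyl counterpart. In this assay compound 1 reaches only > 100000 nM, which is a limit of the assay and not a number. The change phenyl in place of 4-methylbenzyl on an amide-type nitrogen thus produces an at least 3.5-fold higher number from compound 2 to compound 1 (0.54 log units; beyond the scatter), a step that rests on (the limit of > 100000 nM in this assay, at which 1 of the 3 values shown sits).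

Compound 3 `COc1cc([C@H]2C[C@]2(CO)C(=O)NCc2ccc(C)cc2)cc(OC)c1OC` keeps the 4-methylbenzyl amide on a second core; the difference between the two cores is not broken down here. In this assay compound 3 gives 57800 nM, a weaker inhibition than compound 2.

Compound 4 `COc1cc([C@H]2C[C@]2(CO)C(=O)Nc2ccccc2)cc(OC)c1OC` applies the same change, (phenyl in place of 4-methylbenzyl on an amide-type nitrogen), to compound 3, at a place described in identical terms. Compound 4 is expected to show a 3.1-fold higher number from compound 3 to compound 4 (0.49 log units; beyond the scatter), a step in the direction and of the size of an at least 3.5-fold higher number from compound 2 to compound 1 (0.54 log units; beyond the scatter). Because compound 3 starts at 57800 nM, such a step is expected to carry compound 4 to an even weaker inhibition. In this assay compound 4 is estimated at 180000 nM, most probably reported only as a limit, within 80000 nM to 500000 nM.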

Compound 4, half-maximal inhibitory concentration: > 100000 nM
Compound 4 ended at the assay's limit (the forecaster's own chance of this, stated with the estimate: 75%); the middle value does not contradict the limit.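

Phenyl in place of 4-methylbenzyl on the amide-type nitrogen gives an at least 1.7-fold higher number from compound 3 to compound 4 (0.23 log units; that floor lies within the scatter) in this assay, so the second core does not contradict the direction seen on the first, but this floor alone does not establish that the change carries over. Compound 4 gives > 100000 nM, which is a limit of the assay and not a number. The two steps can be compared only as floors, so any similarity in size between the two cores remains unshown: the same change on two cores in this assay, an at least 3.5-fold higher number (0.54 log units; beyond the scatter) from compound 2 to compound 1 and an at least 1.7-fold higher number (0.23 log units; that floor lies within the scatter) from compound 3 to compound 4; the limit leaves it open whether they differ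

On these data alone, with the phenyl amides on both cores at the limit, the true size of the step remains open on each core. Also open, as far as these compounds go, is whether an unsubstituted benzyl group or a phenethyl group on the amide-type nitrogen would give values inside the range of this assay on both cores, and so allow the change to be compared directly.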